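Swapping the aryl group on the pyrazole core of compound 2

A few compounds are considered here, and "the series" means these few. Any claim that something is new, unique, unknown or untested is made for them only; others in the source may bear on it.

Of the compounds shown here, three of a shared core have been tested in a functional assay on BJAB cells (Homo sapiens) for antiproliferative activity, with a stated time of 4 days; on this read-out higher numbers stand for an effect only at larger amounts of compound and lower numbers for an effect already at smaller amounts. Compound 1 `COC(=O)c1c(Cc2ccccc2[N+](=O)[O-])c(C)nn1-c1nc(-c2ccc(Cl)c(Cl)c2)cs1` gives 377000 nM in this assay. Compound 2 `COc1ccccc1-c1c(C)nn(-c2nc(-c3ccc(Cl)c(Cl)c3)c(SC(C)C)s2)c1C(=O)O` gives 14700 nM in this assay, the lowest of the two numbers recorded, and its gap to compound 1 lies beyond the usual scatter of the measurement. Compound 3 `Cc1c(-c2cc(Cl)cc(Cl)c2)c(C(=O)O)nn1-c1nc(-c2ccncc2)c(SC(C)C)s1` is recorded in this assay as "not active" (no number reported), without a number. Compound 3 differs from compound 2 in more than one place, so its result cannot be tied to a single change.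

The next compound, compound 4 `Cc1nn(-c2nc(-c3ccc(Cl)c(Cl)c3)c(SC(C)C)s2)c(C(=O)O)c1-c1cncc(C#N)c1`, differs from compound 2 in a single place: 5-cyanopyridin-3-yl in place of 2-methoxyphenyl on an aromatic carbon. Among the measured compounds shown here, no measured pair in this set isolates such a swap, so there is no direct precedent for its size or direction. Given that compound 2 sits at 14700 nM and that nothing in the data points one way or the other, compound 4 is expected to land near compound 2, with a step of a 1.4-fold higher number from compound 2 to compound 4 (0.13 log units; within the scatter) that may fall within the scatter. Compound 4 is therefore estimated at 20000 nM in this assay, within a range from 5000 nM to 80000 nM.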

Compound 4, half-maximal effective concentration: 20000 nM
Beside the measured number, compound 4's estimate shows no gap at the digits printed; low and high end bracket the measured number.
By their numbers in this assay, from the lowest: compounds 2 and 4 (each within the scatter of the next); then compound 1.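

In this assay, 5-cyanopyridin-3-yl in place of 2-methoxyphenyl gives a 1.4-fold higher number from compound 2 to compound 4 (0.13 log units; within the scatter), so compound 2 and compound 4 cannot be told apart on this read-out. Among the compounds shown here, this is the first reading of a single change in the set, as the earlier compounds differ from one another in more than one place. It shows that, on the aromatic carbon next to the ring atom that bears a carboxy group and next to the ring atom that bears a methyl group, a carbon-only ring with a methoxy group and a ring with one hetero atom and a nitrile can be exchanged with no difference beyond the scatter, and no available measurement explains this outcome.

Both groups compared at this carbon are six-membered aromatic rings, so the compounds shown leave open whether a morpholine, an amine or a short alkyl chain there would give a number in the same range. They also leave open how this carbon would respond if an amide stood in place of the carboxy group.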